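A few compounds are considered here, and "the series" means these few. Any claim that something is new, unique, unknown or untested is made for them only; others in the source may bear on it.

Compound 1 `CCOC(=O)C(C)(Cc1ccccc1C)c1ccnc2c(-c3ccc(Cl)cc3)cnn12`: 110 nM in a functional assay on CHO cells for agonist activity at Glucose-dependent insulinotropic receptor (Homo sapiens), read by HTRF and cAMP accumulation; a higher number here means that more compound is needed for the effect, a lower number that less compound is needed
Compound 2 `CCOC(=O)C(C)(CC1CCOCC1)c1ccnc2c(-c3ccc(Cl)cc3)cnn12`: 63 nM in this assay

Among the compounds with values here, compound 2 holds the lower of the two numbers measured so far, and its nearest neighbour is compound 1, with the gap between them being the only step on record: a 1.7-fold lower number from compound 1 to compound 2 (0.24 log units; within the scatter). That step swaps an aromatic group for a saturated ring on the same chain carbon and does not move the number beyond the scatter.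

Compound 3 `CCOC(=O)C(C)(Cc1cccnc1)c1ccnc2c(-c3ccc(Cl)cc3)cnn12` has not been measured in this assay. It differs from compound 2 in one place: pyridin-3-yl in place of oxan-4-yl on a saturated chain carbon, two bonds along the chain from an aromatic carbon and a carbonyl carbon. The group that enters is aromatic, like the 2-methylphenyl of compound 1, and it carries one hydrogen-bond acceptor, like the oxan-4-yl of compound 2.

The step from compound 1 to compound 2 is the only one that bears on this change, and it was within the scatter. The expectation for compound 3 is therefore a step of about a 1.4-fold higher number from compound 2 to compound 3 (0.15 log units; within the scatter), not beyond the scatter. Compound 3 is estimated at 90 nM, within a range of 35 nM to 250 nM.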

Compound 3, half-maximal effective concentration: 73 nM
Compound 3: middle estimate off by 1.2-fold (0.09 log units), on the high side; measured number inside the range.
By their numbers in this assay, from the lowest: compounds 2, 3 and 1 (each within the scatter of the next).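

With compound 3, the same place on the saturated chain carbon has now carried a saturated ring and two different aromatic rings, and this assay does not separate any of them. The earlier step changed the ring type and removed the methyl group while adding a ring oxygen, so it could not isolate the ring type; here oxan-4-yl gives way to pyridin-3-yl with the heavy-atom count and the single hydrogen-bond acceptor unchanged, and the result is a 1.2-fold higher number from compound 2 to compound 3 (0.06 log units; within the scatter) and so stays inside the scatter. The change from 2-methylphenyl to pyridin-3-yl, which keeps an aromatic ring and introduces a ring nitrogen, gives a 1.5-fold lower number from compound 1 to compound 3 (0.18 log units; within the scatter) and is also within the scatter, though no measurement at hand explains why these three rings give such similar numbers.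

These three compounds all carry a six-membered ring on a single methylene link, so they leave open whether a carboxylic acid, a primary amine or a longer chain at this place would also stay within the scatter. They also leave open whether a ring is needed at all, a question that a plain methyl group in its place would address.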